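The source may hold more compounds than are shown below. What is called first, only, known or untested is meant among the compounds shown, and "the series" means these compounds.

Measured so far:
compound 1 `COc1cccc(OC)c1OCCNCCOc1ccccc1OCc1ccccc1` — 8.3
compound 2 `COc1cccc(OC)c1OCCNCCOc1ccccc1OCc1ccc(Cl)cc1` — 8.06

Among the compounds with values here, in a functional assay on spleen for antagonist activity at Alpha-1B adrenergic receptor (Rattus norvegicus) (a lower number here means a less potent compound, a higher number a more potent compound, by a factor of ten per unit of this negative logarithm), compound 1 stands at the top of these two numbers, and the only neighbour, compound 2, lies a number 0.24 log units lower from compound 1 to compound 2 (within the scatter), so the pair is not separated.

Compound 3 `COc1cccc(OC)c1OCCNCCOc1ccccc1OCc1cccc(C)c1` differs from compound 1 by methyl in place of hydrogen on an aromatic carbon. Within the data shown here, the one measured step that bears on it is the change on the same ring, chloro for hydrogen on an aromatic carbon, which gave a number 0.24 log units lower from compound 1 to compound 2 (within the scatter). Among the measured compounds shown here, no step here reaches beyond the scatter, so for compound 3 no shift beyond the scatter is expected in this assay, a number 0.10 log units lower from compound 1 to compound 3 (within the scatter).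

Estimate for compound 3: 8.2, range 7.7 to 8.7.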

Compound 3, negative logarithm of the antagonist equilibrium constant: 8.2
Compound 3: the middle estimate sits on the measured number at the digits printed, within the range that was stated.
By their numbers in this assay, from the lowest: compounds 2, 3 and 1 (each within the scatter of the next).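

In this assay, going from phenyl to 3-methylphenyl within the benzyloxy group stays within the scatter (a number 0.10 log units lower from compound 1 to compound 3 (within the scatter)), so this place, meta to a large group, accepts a methyl without a separable shift. Exchanging 4-chlorophenyl for 3-methylphenyl also gives no separation (a number 0.14 log units higher from compound 2 to compound 3 (within the scatter)), even though both the group and its place change. Nothing measured here explains this flatness. Open, on these data alone, is whether an amine, a carboxylic acid or a methoxy at this place would move the number beyond the scatter. Also open, as far as these compounds go, is whether methyl and chloro read alike on the same ring carbon.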